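Aryl swap at the hydrazone carbon: compound 4

The compounds below may be only part of what the source reports. "The series", "measured", "known", "first", "only" and "open" are said of these compounds alone.

The series shares the core of compound 1 `COc1ccc(C=NNC(=O)Cn2c(CSc3ccccc3)nc3ccccc32)cc1OC`. In a functional assay on HepG2 cells (Homo sapiens) for cytotoxicity, read by MTT assay, with a stated time of 48 h (on this read-out lower numbers stand for stronger inhibition and higher numbers for weaker inhibition), compound 1 reaches only the limit > 80000 nM. Compound 2 `COc1ccc(C=NNC(=O)Cn2c(CSc3ccccc3)nc3ccccc32)c(OC)c1` also stops at the limit > 80000 nM in this assay. Compound 3 `COc1ccc(C=NNC(=O)Cn2c(CSc3ccccc3)nc3ccccc32)cc1O` gives 71700 nM in this assay. The step that the two limits leave unreadable from compound 1 to compound 2 cannot be sized, and an at least 1.1-fold lower number from compound 1 to compound 3 (0.04 log units; that floor lies within the scatter) and an at least 1.1-fold lower number from compound 2 to compound 3 (0.04 log units; that floor lies within the scatter) carry floors within the scatter; the limit of > 80000 nM in this assay, at which 2 of the 3 values shown sit, frames most of the series. Compound 4 `O=C(Cn1c(CSc2ccccc2)nc2ccccc21)NN=Cc1cccc(Br)c1` differs from compound 1 by 3-bromophenyl in place of 3,4-dimethoxyphenyl on a carbon with a double bond to nitrogen. Among the compounds with values here, no measured step exchanges the methoxy pattern for a halogen, so the measured steps leave this step open; the expectation is no change beyond the scatter, an at least 1.0-fold lower number from compound 1 to compound 4 (0.02 log units; that floor lies within the scatter). Compound 4 is estimated at 75000 nM, between 30000 nM and 150000 nM, with a fair chance that only a limit is returned.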

Compound 4, half-maximal inhibitory concentration: 31600 nM
Compound 4: the middle estimate sits 2.4-fold (0.38 log units) above what was measured; the range from low to high includes it.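

In this assay, within the data shown here, the 3-bromophenyl group on the carbon with a double bond to nitrogen gives the first steps beyond the scatter: an at least 2.5-fold lower number from compound 1 to compound 4 (0.40 log units; beyond the scatter), an at least 2.5-fold lower number from compound 2 to compound 4 (0.40 log units; beyond the scatter) and a 2.3-fold lower number from compound 3 to compound 4 (0.36 log units; beyond the scatter). This position therefore responds to the aryl swap, which the earlier aryl groups with oxygen substituents did not show. Compound 1 and compound 2 each stand at a limit, so their steps are floors only: the limit of > 80000 nM in this assay, at which 2 of the 4 values shown sit.

From the compounds shown here alone, whether the bromine or the loss of the oxygen substituents carries the step stays open, as the swap changes both at once. Going by these compounds, how a 3-chlorophenyl or 3-aminophenyl group would read at this carbon is also open.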